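The compounds below may be only part of what the source reports. "The series", "measured", "known", "first", "only" and "open" are said of these compounds alone.

Working notes on the series: compound 1 `CCCCCCCCn1cc(COC[C@@H]2OC[C@H](N)[C@@H]2O)nn1`, compound 2 `CCCCCCCCCCCCn1cc(COC[C@@H]2OC[C@H](N)[C@@H]2O)nn1`, compound 3 `CCCCCCCCCCCCCCCCn1cc(COC[C@@H]2OC[C@H](N)[C@@H]2O)nn1` and compound 4 `CCCCCCCCCCCCCCCCCCn1cc(COC[C@@H]2OC[C@H](N)[C@@H]2O)nn1` share one core and differ only in the length of the saturated chain. In a functional assay on MGC-803 cells (Homo sapiens) for antiproliferative activity, read by MTT assay, with a stated time of 48 h (on this read-out lower numbers stand for stronger inhibition and higher numbers for weaker inhibition), compound 1 gives 70400 nM, compound 2 gives 21400 nM and compound 3 gives 27900 nM. Compound 3 thus stands level with compound 2 and well clear of compound 1, as a 2.5-fold lower number from compound 1 to compound 3 (0.40 log units; beyond the scatter) shows. Compound 4 differs from compound 3 by ethyl in place of hydrogen on a saturated chain carbon, ten or more bonds along the chain from an aromatic nitrogen.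

Going by the values given here, the closest precedent is the change at the same reach of the chain, a 1.3-fold higher number from compound 2 to compound 3 (0.12 log units; within the scatter). The modest gain, a 3.3-fold lower number from compound 1 to compound 2 (0.52 log units; beyond the scatter), came from a change nearer the start of the chain and bears less directly. Three compounds are a thin basis, so a shift in either direction stays possible. In this assay, no change beyond the scatter is expected, and the expected step is a 1.1-fold higher number from compound 3 to compound 4 (0.03 log units; within the scatter). For compound 4 the estimated value is 30000 nM, with an expected range of 14000 nM to 65000 nM.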

Compound 4, half-maximal inhibitory concentration: 15400 nM
Estimate against measurement, compound 4: 1.9-fold (0.29 log units) above, within the range that was stated.
By their numbers in this assay, from the lowest: compounds 4, 2 and 3 (each within the scatter of the next); then compound 1.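

In this assay, ethyl in place of hydrogen on a saturated chain carbon, ten or more bonds along the chain from an aromatic nitrogen, leaves the read-out within the scatter (a 1.8-fold lower number from compound 3 to compound 4 (0.26 log units; within the scatter)), and hexyl at the same place does too (a 1.4-fold lower number from compound 2 to compound 4 (0.14 log units; within the scatter)). The level seen for compound 2 and compound 3 therefore extends to compound 4, and among the compounds shown only compound 1 stands apart, with the decyl difference beyond the scatter but still modest (a 4.6-fold lower number from compound 1 to compound 4 (0.66 log units; beyond the scatter)). No measurement shown offers a cause for these steps.

Going by these compounds, whether a longer chain than that of compound 4 holds this level remains open. So does whether a carboxylic acid or an amine in place of ethyl at this place reads the same.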